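This account rests on a few compounds, and the source may have more. Where it says the series, first, only, none or still open, it means among the compounds named here.

Compound 1 `CCCCOc1noc2c1CNCC2` gives 7.6
Compound 2 `C=C(Br)COc1noc2c1CNCC2` gives 7.6

In a physicochemical assay for acid dissociation, compound 2 at 7.6 stands level with compound 1, its nearest neighbour. Compound 3 `CCCOc1noc2c1CNCC2` differs from compound 2 by ethyl in place of 1-bromoethenyl on a saturated chain carbon bound to an oxygen on an aromatic ring with ethyl in place of 1-bromoethenyl on a saturated chain carbon bound to an oxygen on an aromatic ring. Going by the values given here, one measured step bears on this place: no change at the digits printed from compound 1 to compound 2 (within the scatter) lies within the scatter. In this assay the estimated no change at the digits printed from compound 2 to compound 3 (within the scatter) therefore means no expected change beyond the scatter. For compound 3 the expected value is 7.6 with an estimated range from 7.3 to 7.9 in this measurement.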

Compound 3, acid dissociation constant: 7.6
For compound 3 middle estimate and measured number coincide at the digits printed; low and high end bracket the measured number.
By their numbers in this assay, from the lowest: compounds 1, 2 and 3 (each within the scatter of the next).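

In this assay, ethyl in place of 1-bromoethenyl gives no change at the digits printed from compound 2 to compound 3 (within the scatter), and hydrogen in place of methyl, three bonds along the chain from the oxygen, gives no change at the digits printed from compound 1 to compound 3 (within the scatter). The read-out therefore does not separate the three chains at this position, whether the chain is saturated or carries the double bond and bromine. Nothing on hand offers an explanation for this flat result.

Still open, as far as these compounds go, is whether a longer chain would leave the number equally unmoved. The same question stands for a chain ending in an amine or a carboxylic acid.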